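From cyclopentyl to 1-(methoxymethyl)ethyl on a shared core

The source may report more compounds than this note shows. Statements on the series, on what has been measured and on what is new or still open speak of the compounds shown alone.

Compound 1 `[O-][n+]1nc(NC2CC2)[n+]([O-])c2ccccc21` gives 21 ug/mL
Compound 2 `CC(C)(C)Nc1n[n+]([O-])c2ccccc2[n+]1[O-]` gives 8 ug/mL
Compound 3 `[O-][n+]1nc(NC2CCCC2)[n+]([O-])c2ccccc21` gives 10 ug/mL

These numbers come from an ADME assay on Vero cells (Chlorocebus sabaeus) for cytotoxicity, read by CellTiter-Glo, with a stated time of 72 h (on this read-out lower numbers stand for higher toxicity in this test and higher numbers for lower toxicity in this test), and span a narrow band. Compound 3 sits at 10 ug/mL, level with compound 2 within the usual scatter, while compound 1 stands apart on the higher side.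

Compound 4 `COCC(C)Nc1n[n+]([O-])c2ccccc2[n+]1[O-]` has not been measured yet. It keeps the shared core and exchanges one group on a nitrogen on an aromatic ring: 1-(methoxymethyl)ethyl in place of cyclopentyl on a nitrogen on an aromatic ring. In words, this is 1-(methoxymethyl)ethyl in place of cyclopentyl. Among the compounds with values here, three measured steps bear on this, all of them swaps at the same place. One modest step is a 2.1-fold lower number from compound 1 to compound 3 (0.32 log units; beyond the scatter), and another, a 1.3-fold higher number from compound 2 to compound 3 (0.10 log units; within the scatter), stays within the scatter. Within the data shown here, none of the measured compounds carries a methoxymethyl group, so no step speaks directly to this one. Judged by the largest step seen, a 2.6-fold lower number from compound 1 to compound 2 (0.42 log units; beyond the scatter), only a small move is expected in this assay, leaning slightly upward and not beyond the scatter. The expected step is a 1.4-fold higher number from compound 3 to compound 4 (0.15 log units; within the scatter). Compound 4 is estimated at 14 ug/mL, within an expected range of 6 ug/mL to 32 ug/mL.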

Compound 4, half-maximal cytotoxic concentration: > 50 ug/mL
Compound 4 was reported as a limit (the forecaster's own chance of this, stated with the estimate: 3%); middle value at least 3.5-fold (0.55 log units) away from the limit.
By their numbers in this assay, from the lowest: compounds 2 and 3 (each within the scatter of the next); then compound 1. At a limit, above all of these: compound 4.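

In this assay compound 4 is reported only as a limit and not as a number: the limit of > 50 ug/mL in this assay, at which 1 of the 4 values shown sits. The earlier swaps among cyclopropyl, tert-butyl and cyclopentyl moved the number only a little, whereas the new group gives an at least 5.0-fold higher number from compound 3 to compound 4 (0.69 log units; beyond the scatter), together with an at least 6.2-fold higher number from compound 2 to compound 4 (0.79 log units; beyond the scatter) and an at least 2.3-fold higher number from compound 1 to compound 4 (0.37 log units; beyond the scatter), so the group on this nitrogen can shift the reading further than the first three compounds showed. Leaving and entering groups have the same number of heavy atoms, so that count does not separate them; what differs is that the carbon ring is gone and the open 1-(methoxymethyl)ethyl chain brings a hydrogen-bond acceptor.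

Since compound 4 loses the ring and gains the oxygen in a single change, the compounds shown cannot tell which of the two goes with the higher number, and an open all-carbon chain or a ring containing an ether oxygen would be needed to separate them. From the compounds shown here alone, how far the true value of compound 4 lies past its limit also stays unknown, and so does the full size of its steps.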